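Changing the ring group on compound 3

A few compounds are considered here, and "the series" means these few. Any claim that something is new, unique, unknown or untested is made for them only; others in the source may bear on it.

compound 1 `CC[C@@H]1C[C@H](CC)CN(CCCNC(=O)C2CCN(Cc3nc(-c4ccccc4C)oc3C)CC2)C1`: 0.0917 h
compound 2 `Cc1ccccc1-c1nc(CN2CCC(C(=O)NCCCN3CC(C)(C)CC(C)(C)C3)CC2)c(C)o1`: 0.095 h
compound 3 `Cc1ccccc1-c1nc(CN2CCC(C(=O)NCCCN3CCCC(C(C)C)C3)CC2)c(C)o1`: 0.323 h

In an ADME assay on microsomes from liver (Rattus norvegicus) for metabolic stability, read by LC-MS, using NADPH, at 37 degrees C (on this read-out lower numbers stand for a shorter-lived compound and higher numbers for a longer-lived compound), compound 3 gives 0.323 h, the highest of the three numbers. The next molecule, compound 4 `Cc1ccccc1-c1nc(CN2CCC(C(=O)NCCN3C[C@H](C)C[C@H](C)C3)CC2)c(C)o1`, differs from it in one place: a group of 8 heavy atoms (7 carbon, 1 nitrogen; one six-membered non-aromatic ring with 1 hetero atom) in place of a group of 10 heavy atoms (9 carbon, 1 nitrogen; one six-membered non-aromatic ring with 1 hetero atom), on a saturated chain carbon, two bonds along the chain from an amide-type nitrogen. This puts a 3,5-dimethylpiperidin-1-yl group on a saturated chain carbon, two bonds along the chain from an amide-type nitrogen.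

Among the compounds with values here, three measured steps bear on this change. Exchanging one group for another with the same heavy-atom count gave a 1.0-fold higher number from compound 1 to compound 2 (0.02 log units; within the scatter). Moving to a group with fewer heavy atoms gave a 3.5-fold higher number from compound 1 to compound 3 (0.55 log units; beyond the scatter) and a 3.4-fold higher number from compound 2 to compound 3 (0.53 log units; beyond the scatter), both modest. Within the data shown here, those steps sit three bonds along the chain, and no measured compound carries the new group at the new place, so three compounds offer only a loose guide. The group shrinks again here, so a small further rise seems the likelier direction, on the evidence of a 3.4-fold higher number from compound 2 to compound 3 (0.53 log units; beyond the scatter). The expected step is a 1.4-fold higher number from compound 3 to compound 4 (0.14 log units; within the scatter), and a clear change is not expected. The estimated half-life for compound 4 is 0.45 h, with an expected range from 0.17 h to 1.1 h.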

Compound 4, half-life: > 0.5 h
Compound 4 ended at the assay's limit (the forecaster's own chance of this, stated with the estimate: 3%); middle value at least 1.1-fold (0.04 log units) from the limit.
By their numbers in this assay, from the lowest: compounds 1 and 2 (each within the scatter of the next); then compound 3. At a limit, above all of these: compound 4.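

In this assay, compound 4 is read only as a limit of the assay, not as a number: the limit of > 0.5 h in this assay, at which 1 of the 4 values shown sits.

Even so, the earlier compounds held no example of a group two bonds along the chain from an amide-type nitrogen, and this first one does not bring the half-life down: the result is an at least 1.5-fold higher number from compound 3 to compound 4 (0.18 log units; that floor lies within the scatter), a floor too small to establish a real gain on its own, while the comparisons with the two larger ring groups give an at least 5.2-fold higher number from compound 2 to compound 4 (0.72 log units; beyond the scatter) and an at least 5.4-fold higher number from compound 1 to compound 4 (0.73 log units; beyond the scatter). Among these four compounds, the smallest group at the new place therefore sits beyond the scatter of compounds 1 and 2, extending the earlier rise seen with compound 3, although the step from compound 3 does not confirm that trend by itself.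

From the compounds shown here alone, what remains open is how much of this rise belongs to the smaller group and how much to its place, a question that 3,5-dimethylpiperidin-1-yl three bonds along the chain would address. A plain piperidine or a morpholine ring at the new place could also show whether the two methyl groups matter.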